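Adding a 3-Methoxyphenyl Group to Two Related Sulfonamides

The source may hold more compounds than are shown below. What is called first, only, known or untested is meant among the compounds shown, and "the series" means these compounds.

Compound 1 `O=C1COc2ccc(-c3cccc(NS(=O)(=O)c4ccc(F)cc4)c3)cc2N1` was examined in a functional assay on HCT-116 cells (Homo sapiens) for antiproliferative activity, read by MTT assay, with a stated time of 72 h; on this read-out lower numbers stand for stronger inhibition and higher numbers for weaker inhibition. In this assay compound 1 gives only a limit, > 40000 nM, rather than a number. Compound 2 `COc1ncc(-c2ccc3c(c2)NC(=O)CO3)cc1NS(=O)(=O)c1ccc(F)cc1` rests on a different core, and the difference between the two cores is not broken down here. In this assay compound 2 gives 24900 nM. Compound 3 `COc1cccc(N2C(=O)COc3ccc(-c4cnc(OC)c(NS(=O)(=O)c5ccc(F)cc5)c4)cc32)c1` is compound 2 carrying the change (3-methoxyphenyl in place of hydrogen on an amide-type nitrogen in a ring). In this assay compound 3 gives only a limit, > 40000 nM. The measured step is an at least 1.6-fold higher number from compound 2 to compound 3 (0.20 log units; that floor lies within the scatter), and it appears as a floor because of the limit of > 40000 nM in this assay, at which 2 of the 3 values shown sit.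

Compound 4 `COc1cccc(N2C(=O)COc3ccc(-c4cccc(NS(=O)(=O)c5ccc(F)cc5)c4)cc32)c1` has not yet been measured in this assay. For the measured compounds named here, it carries the same change as the one made from compound 2 to compound 3, here on the core of compound 1, namely (3-methoxyphenyl in place of hydrogen on an amide-type nitrogen in a ring). Going by the values given here, the one measured example of this change gives no sign of a stronger effect, and compound 1 itself already returns a limit in this assay. Among the compounds with values here, the step from compound 1 to compound 4 is therefore expected to be no more than a step that the limit leaves unreadable from compound 1 to compound 4, which is to be read beside the measured at least 1.6-fold higher number from compound 2 to compound 3 (0.20 log units; that floor lies within the scatter). Compound 4 is expected to give about 60000 nM in this assay, most likely reported again as a limit, with an expected range from 25000 nM to 200000 nM.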

Compound 4, half-maximal inhibitory concentration: > 40000 nM
Compound 4 was reported as a limit; the forecaster's own chance of this, stated with the estimate: 85%; the middle value does not contradict the limit.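

Compound 1 and compound 4 both stop at a limit in this assay, so no step can be read between them: the limit of > 40000 nM in this assay, at which 3 of the 4 values shown sit.

The compounds shown leave open whether 3-methoxyphenyl in place of hydrogen on the amide-type nitrogen changes the result in this assay on the core of compound 1 at all, and by how much.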